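The source may report more compounds than this note shows. Statements on the series, on what has been measured and on what is new or still open speak of the compounds shown alone.

In an ADME assay on Caecum (Rattus norvegicus, strain Sprague-Dawley) for metabolic stability, read by LC-MS, tested at 10 uM (a lower number here means that the compound disappears faster, a higher number that the compound lasts longer), compound 1 `C[C@@H](N[C@H]1CCN(c2ccc(C(=O)NCCCCNC(CO)(CO)CO)cc2)C1)c1cccc2ccccc12` gives 8 h while compound 2 `C[C@@H](N[C@H]1CCN(c2ccc(C(=O)N(C)[C@@H](O)[C@H](O)[C@H](O)[C@@H](O)CO)cc2)C1)c1cccc2ccccc12` gives 11 h and these two values lie within the usual scatter of each other. Compound 3 `C[C@@H](N[C@H]1CCN(c2ccc(C(=O)NCCCN3CCC(C(=O)O)CC3)cc2)C1)c1cccc2ccccc12` gives > 12 h and that figure is a limit of the assay, not a number. So compound 3 stands at the limit of > 12 h in this assay, at which 1 of the 3 values shown sits, and its exact place is unknown.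

Compound 4 `C[C@@H](N[C@H]1CCN(c2ccc(C(=O)N[C@H](CCCCN)C(=O)O)cc2)C1)c1cccc2ccccc12` carries 5-amino-1-carboxypentyl in place of 3-(4-carboxypiperidin-1-yl)propyl on an amide-type nitrogen while the rest of the structure stays the same. Among the measured compounds shown here, the one measured step that bears on this change also alters the same side chain: it is an at least 1.5-fold higher number from compound 1 to compound 3 (0.17 log units; that floor lies within the scatter) and it gives no firm size for a change of this kind. No step beyond the scatter is expected in this assay here. The expected change is an at least 1.2-fold lower number from compound 3 to compound 4 (0.07 log units; that floor lies within the scatter) and its true size stays uncertain while compound 3 has only a limit. The estimated half-life of compound 4 is 10 h with an expected range from 5 h to 20 h in this estimate.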

Compound 4, half-life: 4.3 h
Compound 4: middle estimate off by 2.3-fold (0.37 log units), on the high side; the whole stated range lies above it.
By their numbers in this assay, from the lowest: compounds 4, 1 and 2 (each within the scatter of the next, the first and the last beyond it). At a limit, above all of these: compound 3.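

In this assay, among the compounds shown here, what the amide-type nitrogen carries can matter: 5-amino-1-carboxypentyl in place of 3-(4-carboxypiperidin-1-yl)propyl gives an at least 2.7-fold lower number from compound 3 to compound 4 (0.44 log units; beyond the scatter), a change beyond the scatter that the earlier compounds did not show. The side chain of compound 4 also separates from that of compound 2, with a 2.6-fold lower number from compound 2 to compound 4 (0.41 log units; beyond the scatter), but not from that of compound 1, with a 1.9-fold lower number from compound 1 to compound 4 (0.27 log units; within the scatter), so it is not set apart from every earlier side chain. The value of compound 3 is a limit, not a number, so its step gives only a floor: the limit of > 12 h in this assay, at which 1 of the 4 values shown sits.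

On these data alone, it remains open whether a chain ending in the amine alone, or in the carboxylic acid alone, would behave like 5-amino-1-carboxypentyl. Also open, as far as these compounds go, is how a piperidine ring without the carboxylic acid would compare with 4-carboxypiperidin-1-yl.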